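The compounds below may be only part of what the source reports. "The series", "measured", "known", "first", "only" and "open" are said of these compounds alone.

Two close relatives of dichloroacetanilide have been tested for their ability to hold back the growth of a human lung cancer cell line. Compound 1 `O=C(Nc1ccccc1[N+](=O)[O-])C(Cl)Cl` carries a nitro group on the aromatic ring, and in a functional assay on A549 cells (Homo sapiens) for antiproliferative activity, read by MTT assay, with a stated time of 72 h (a lower number here means a stronger inhibitor, a higher number a weaker inhibitor), compound 1 gives 198000 nM. Compound 2 `O=C(Nc1cccc(Cl)c1)C(Cl)Cl` carries a chloro group instead, and in this assay compound 2 gives 14800 nM. Of the two numbers available, compound 2 has the lower one, and its gap to compound 1 is wide enough to sit beyond the usual scatter of repeated measurements. Compound 3 `O=C(Nc1cccc(OC(F)(F)F)c1)C(Cl)Cl` keeps the shared core of compound 2 and differs from it in a single place: trifluoromethoxy in place of chloro on an aromatic carbon. Going by the values given here, no measured pair shows what this particular exchange does in this assay, so the expectation rests on the change itself, which swaps one uncharged substituent for another without adding a hydrogen-bond donor. The step is expected to be small, in either direction, and is estimated as a 1.0-fold higher number from compound 2 to compound 3 (0.01 log units; within the scatter). Compound 3 is accordingly estimated at 15000 nM, within a range from 5000 nM to 50000 nM.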

Compound 3, half-maximal inhibitory concentration: 15100 nM
For compound 3 the middle estimate is 1.0-fold (0.00 log units) below the measured one, and the stated range covers the measured number.
By their numbers in this assay, from the lowest: compounds 2 and 3 (each within the scatter of the next); then compound 1.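

In this assay, the exchange of chloro for trifluoromethoxy gives (a 1.0-fold higher number from compound 2 to compound 3 (0.01 log units; within the scatter)), so this read-out does not separate the two compounds. Going by these compounds alone, this pair is the first direct look at a single exchange at this aromatic carbon, and the change is not a trivial one on paper: trifluoromethoxy brings 5 heavy atoms and 1 hydrogen-bond acceptor, where chloro has 1 heavy atom and 0 hydrogen-bond acceptors, yet the two numbers lie within the scatter of each other. Nothing at hand explains why these two different groups give such similar numbers.

Both groups have no net charge and 0 hydrogen-bond donors, so the compounds shown leave open whether an amine or a carboxylic acid on this same carbon would give a number clearly apart from those of compound 2 and compound 3. They also leave open how far this tolerance extends to larger groups, such as a longer alkoxy chain, and whether trifluoromethoxy would give a similar number elsewhere on the ring.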